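Bringing an Aromatic Ring Back to the Amine Nitrogen

The compounds below may be only part of what the source reports. "The series", "measured", "known", "first", "only" and "open" are said of these compounds alone.

In a functional assay on MCF7 cells (Homo sapiens) for inhibition, read by sulforhodamine B assay (a lower number here means a stronger inhibitor, a higher number a weaker inhibitor), compound 1 `O=C1C=C(Nc2cccc(F)c2)C(=O)c2c1nc1n2[C@H]2OC[C@@H](O)[C@H]2OC1` gives 5500 nM. Compound 2 `O=C1C=C(NC2CCCC2)C(=O)c2c1nc1n2[C@H]2OC[C@@H](O)[C@H]2OC1` reaches only a limit of the assay, > 16000 nM, so it has no exact number. Among the compounds with values here, the one measured step that bears on the next change is an at least 2.9-fold higher number from compound 1 to compound 2 (0.46 log units; beyond the scatter), with cyclopentyl in place of 3-fluorophenyl on an amine nitrogen. Compound 3 `COc1ccc(NC2=CC(=O)c3nc4n(c3C2=O)[C@H]2OC[C@@H](O)[C@H]2OC4)cc1` carries 4-methoxyphenyl in place of cyclopentyl on that nitrogen: 4-methoxyphenyl in place of cyclopentyl on an amine nitrogen. This again puts an aromatic ring there, so that earlier step is expected to largely reverse. The expected change, towards a lower number, is an at least 2.9-fold lower number from compound 2 to compound 3 (0.46 log units; beyond the scatter). For compound 3 the estimate is 5500 nM, with an expected range of 2000 nM to 15000 nM.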

Compound 3, half-maximal inhibitory concentration: 5420 nM
Compound 3: the middle estimate sits 1.0-fold (0.01 log units) above what was measured, within the range that was stated.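

In this assay, the 3-fluorophenyl and 4-methoxyphenyl groups on the amine nitrogen cannot be told apart, with a 1.0-fold lower number from compound 1 to compound 3 (0.01 log units; within the scatter). Against cyclopentyl, a second aromatic ring now gives an at least 2.9-fold lower number from compound 2 to compound 3 (0.47 log units; beyond the scatter), so this gap holds for both aromatic groups shown. The true size of that gap is unknown, since compound 2 sits at a limit of the assay: the limit of > 16000 nM in this assay, at which 1 of the 3 values shown sits.

On these data alone, whether an unsubstituted phenyl, a pyridine ring or a benzyl group would match these two aromatic groups remains open. So does whether any group on this nitrogen can give a much lower number.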